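Ethyl in place of 2-methylcyclopropyl on the amide carbonyl

The compounds below may be only part of what the source reports. "The series", "measured", "known", "first", "only" and "open" are said of these compounds alone.

In an assay on CHO cells for agonist activity at Neuronal acetylcholine receptor; alpha3/beta4 (Homo sapiens), read by FLIPR and calcium flux (a lower number here means that less compound is needed, a higher number that more compound is needed for the effect), compound 1 `C[C@@H]1C[C@@H]1C(=O)N1CC2CNCC2C1` gives 1400 nM, compound 2 `C[C@@H]1C[C@H]1C(=O)N1CC2CNCC2C1` gives 14000 nM and compound 3 `C[C@H]1C[C@@H]1C(=O)N1CC2CNCC2C1` gives 34000 nM, the highest of the three numbers. The steps of a 10-fold higher number from compound 1 to compound 2 (1.00 log units; beyond the scatter) and a 24-fold higher number from compound 1 to compound 3 (1.39 log units; beyond the scatter) are both beyond the scatter, as is a 2.4-fold higher number from compound 2 to compound 3 (0.39 log units; beyond the scatter); all three concern only the stereocentres within the 2-methylcyclopropyl group. Compound 4 `CCC(=O)N1CC2CNCC2C1` differs from compound 3 by ethyl in place of 2-methylcyclopropyl on a carbonyl carbon. Going by the values given here, no measured step replaces this ring with a chain, so none bears directly on it; the measured steps only show that the number moves widely as the arrangement of the 2-methylcyclopropyl group changes. For compound 4 the expectation is therefore uncertain, and a step of a 5.7-fold lower number from compound 3 to compound 4 (0.75 log units; beyond the scatter) is estimated, placing the value inside the span of the three measured compounds. Compound 4 is expected to give about 6000 nM in this assay, within 1000 nM to 40000 nM.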

Compound 4, half-maximal effective concentration: 18000 nM
The estimate for compound 4 lay 3.0-fold (0.48 log units) below the measured number; the measured number falls inside the stated range.
By their numbers in this assay, from the lowest: compound 1; then compounds 2, 4 and 3 (each within the scatter of the next, the first and the last beyond it).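

With ethyl in place of 2-methylcyclopropyl on the carbonyl carbon, two of the ring-bearing compounds show no separation from the chain: a 1.9-fold lower number from compound 3 to compound 4 (0.28 log units; within the scatter) and a 1.3-fold higher number from compound 2 to compound 4 (0.11 log units; within the scatter). Only compound 1 stands apart, with a 13-fold higher number from compound 1 to compound 4 (1.11 log units; beyond the scatter), so among these compounds the 2-methylcyclopropyl group gives a distinct number only in the configuration of compound 1. Nothing available bears on the reason for these steps. As far as these compounds go, whether unsubstituted cyclopropyl or a longer chain such as butyl at this carbonyl carbon would stand with compound 1 or with compound 4 remains open.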